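Aryl variation on the shared core: outlook for compound 4

The compounds below may be only part of what the source reports. "The series", "measured", "known", "first", "only" and "open" are said of these compounds alone.

Three analogues share one core and differ only in the aryl group on the carbon with a double bond to nitrogen. In a functional assay on HT-29 cells (Homo sapiens) for cytotoxicity, read by MTT assay, with a stated time of 48 h, tested at 12.5 uM (on this read-out lower numbers stand for a weaker effect and higher numbers for a stronger effect at the one concentration tested), compound 1 `CS(=O)(=O)c1ccc(Cc2nnc3n2N=C(c2ccc(Cl)cc2Cl)CS3)cc1` gives 28%, compound 2 `CS(=O)(=O)c1ccc(Cc2nnc3n2N=C(c2ccc(-c4ccccc4)cc2)CS3)cc1` gives 58.2% and compound 3 `CS(=O)(=O)c1ccc(Cc2nnc3n2N=C(c2ccc(O)c(C(N)=O)c2)CS3)cc1` gives 24.8%. Compound 3 carries the lowest of the three numbers; its gap to compound 1 is within the scatter, while compound 2 stands beyond it, higher. Within the data shown here, the one measured step at this position, a number 3.2 percentage points lower from compound 1 to compound 3 (within the scatter), was flat. Compound 4 `CS(=O)(=O)c1ccc(Cc2nnc3n2N=C(c2ccccc2)CS3)cc1` introduces the change (phenyl in place of 3-carbamoyl-4-hydroxyphenyl on a carbon with a double bond to nitrogen). Among the measured compounds shown here, only that flat step bears on it, so the expected step, a number 3.2 percentage points higher from compound 3 to compound 4 (within the scatter), should stay within the scatter. Compound 4 is estimated at 28% in this assay, with a range from 14% to 45%.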

Compound 4, a percentage reported as activity, at one concentration (the size of the read-out at that concentration, not a potency): 42%
Estimate against measurement, compound 4: 14 percentage points below; measured number inside the range.
By their numbers in this assay, from the lowest: compounds 3 and 1 (each within the scatter of the next); then compound 4; then compound 2.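

The position is less flat than the earlier step suggested: in this assay the plain phenyl of compound 4 separates from both substituted aryl groups, with a number 17.2 percentage points higher from compound 3 to compound 4 (beyond the scatter) and with a number 14 percentage points higher from compound 1 to compound 4 (beyond the scatter) as well. Substitution does not lower the number throughout, since compound 2 goes against that reading, with a number 16.2 percentage points lower from compound 2 to compound 4 (beyond the scatter) on the aromatic carbon that loses its phenyl. Nothing available accounts for these steps.

Open, on these data alone, is whether an amine or a carboxylic acid on the phenyl ring would fall with compound 4 or with compound 3. Also open, as far as these compounds go, is whether a group other than phenyl, such as a longer chain, matches compound 2.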